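The source may hold more compounds than are shown below. What is called first, only, known or untested is meant among the compounds shown, and "the series" means these compounds.

Compound 1 `Nc1nc(-c2cccs2)nc2cn(-c3ccccc3)nc12` is the reference point of this pair. In an assay on CHO cells for displacement of a labelled ligand from adenosine receptor A3 (Homo sapiens), read by scintillation counting, with a stated time of 60 min (on this read-out lower numbers stand for stronger inhibition and higher numbers for weaker inhibition), compound 1 gives 9.7 nM, the lowest of the two numbers in hand; the nearest measured neighbour, compound 2 `COc1ccc(-n2cc3nc(-c4cccs4)nc(N)c3n2)cc1`, gives 78 nM. Going by the values given here, the only measured step is an 8.0-fold higher number from compound 1 to compound 2 (0.91 log units; beyond the scatter), which involves a methoxy placed on a different ring from the one altered here and so bears on the new step only as an indication of the spread this core tolerates, not as a direct precedent.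

Compound 3 `Nc1nc(-c2ccc(O)cc2)nc2cn(-c3ccccc3)nc12` carries the change (4-hydroxyphenyl in place of thiophen-2-yl on an aromatic carbon), on the shared core between two ring nitrogen atoms, meta to a fused ring and meta to an amino group. Among the compounds with values here, no measured pair exchanges this aryl group, so the direction rests on the unchanged core and amino group alone; a step of similar size to the one from compound 1 to compound 2, or none beyond the scatter, is both plausible. The expected step is a 2.6-fold higher number from compound 1 to compound 3 (0.41 log units; beyond the scatter). Compound 3 is expected to give 25 nM in this assay, within a range from 5 nM to 120 nM.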

Compound 3, inhibition constant: 432 nM
Estimate against measurement, compound 3: 17-fold (1.24 log units) below, outside the stated range (above it).
By their numbers in this assay, from the lowest: compound 1; then compound 2; then compound 3.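

Notes on the aryl position: in this assay, the group on the aromatic carbon between two ring nitrogen atoms is not a neutral point of the shared core, since 4-hydroxyphenyl in place of thiophen-2-yl gives a 45-fold higher number from compound 1 to compound 3 (1.65 log units; beyond the scatter), with the rest of compound 1 unchanged. Going by these compounds alone, this step is larger than the only other step in hand, an 8.0-fold higher number from compound 1 to compound 2 (0.91 log units; beyond the scatter), so of these two single changes to compound 1, the aryl exchange costs more, although two changes cannot rank the two positions in general. The result therefore shows that this position does not accept every aromatic ring equally, but no measurement in hand explains the rise.

The exchange alters ring size, removes the sulfur and adds a hydroxyl all at once, so the compounds shown do not separate these differences; plain phenyl, furan-2-yl and 4-methoxyphenyl at this position would begin to do so. Also open, on these data alone, is whether the hydroxyl's location matters, which 3-hydroxyphenyl would test, and whether a substituted thiophene, such as 5-methylthiophen-2-yl, keeps the lower number of compound 1.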